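Replacing Methyl with Bromine on an Ecdysone Agonist Ring

The compounds below may be only part of what the source reports. "The series", "measured", "known", "first", "only" and "open" are said of these compounds alone.

Compound 1 `CC(C)(C)N(NC(=O)c1ccccc1Br)C(=O)c1ccccc1Cl`: 316 nM
Compound 2 `CC(C)(C)N(NC(=O)c1ccccc1I)C(=O)c1ccccc1Cl`: 1290 nM
Compound 3 `Cc1ccccc1C(=O)NN(C(=O)c1ccccc1Cl)C(C)(C)C`: 72.4 nM

In an assay on cells for agonist activity at ecdysone receptor (Bombyx mori), read by a luciferase reporter, with a stated time of 24 h (on this read-out lower numbers stand for an effect already at smaller amounts and higher numbers for an effect only at larger amounts of compound), compound 3 stands lowest of the three measured compounds, so it acts at the smallest amount. Its closest neighbour is compound 1, separated by the step of a 4.4-fold lower number from compound 1 to compound 3 (0.64 log units; beyond the scatter); the furthest is compound 2, separated by an 18-fold lower number from compound 2 to compound 3 (1.25 log units; beyond the scatter). The new compound 4 `CC(C)(C)N(NC(=O)c1cccc(Br)c1)C(=O)c1ccccc1Cl` differs from compound 3 in one place: 3-bromophenyl in place of 2-methylphenyl on a carbonyl carbon. Two parts of this change must be weighed. Exchanging methyl for bromine on the same ring carbon has been measured directly as a 4.4-fold lower number from compound 1 to compound 3 (0.64 log units; beyond the scatter), a modest shift that, read backwards, points to a higher number for bromine. Moving the group to another carbon of the ring has not been measured in any pair, and a 4.1-fold higher number from compound 1 to compound 2 (0.61 log units; beyond the scatter) concerns only a different halogen at the same spot. Compound 4 is therefore expected to give a higher number than compound 3, roughly a 6.2-fold higher number from compound 3 to compound 4 (0.79 log units; beyond the scatter), with wide uncertainty. The expected value for compound 4 is 450 nM, between 90 nM and 2500 nM.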

Compound 4, half-maximal effective concentration: 191 nM
Compound 4: middle estimate off by 2.4-fold (0.37 log units), on the high side; the range from low to high includes it.
By their numbers in this assay, from the lowest: compound 3; then compounds 4 and 1 (each within the scatter of the next); then compound 2.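

The bromine can sit on either ring carbon without a clear change: the step from 2-bromophenyl to 3-bromophenyl is (a 1.7-fold lower number from compound 1 to compound 4 (0.22 log units; within the scatter)), so compound 1 and compound 4 cannot be told apart in this read-out. Moving the bromine therefore does not close the gap to the methyl compound, which remains clear (a 2.6-fold higher number from compound 3 to compound 4 (0.42 log units; beyond the scatter)). The 3-bromophenyl group also stands well clear of the 2-iodophenyl group (a 6.8-fold lower number from compound 2 to compound 4 (0.83 log units; beyond the scatter)), so among the groups shown, 2-iodophenyl alone gives a much higher number.

Nothing at hand explains any of these differences. These compounds leave open whether methyl keeps its advantage on the other ring carbon, and how a methoxy group or an amine would behave in place of the bromine.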